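The source may report more compounds than this note shows. Statements on the series, on what has been measured and on what is new or still open speak of the compounds shown alone.

Within the data shown here, compound 1 `Cc1cc(C)c(CN2CCc3c(Cl)cc([C@@H](CO)[C@@H]4CCOC4)c(Cl)c3C2=O)c(=O)[nH]1` is the only compound with a single number in an assay on cells for inhibition of histone-lysine N-methyltransferase EZH2 (Homo sapiens), read by ELISA, with a stated time of 72 h (on this read-out higher numbers stand for weaker inhibition and lower numbers for stronger inhibition), where compound 1 gives 2910 nM. Compound 2 `COC(C)c1cc(Cl)c2c(c1Cl)C(=O)N(Cc1c(C)cc(C)[nH]c1=O)CC2` has two entries in this assay, and compound 2 gives 1310 nM; 427 nM (2 entries); the spread of these entries the several entries of compound 2 in this assay, 1310 nM; 427 nM (2 entries) shows how far repeats of this measurement can drift. Compound 3 `Cc1cc(C)c(CN2CCc3c(Cl)cc([C@@H](CO)[C@H]4CCCO4)c(Cl)c3C2=O)c(=O)[nH]1` differs from compound 1 in one place: oxolan-2-yl in place of oxolan-3-yl on a saturated chain carbon bound to an aromatic carbon and a saturated chain carbon. Among the measured compounds shown here, no measured pair here carries such a change, so the step is expected to stay within the scatter, in no clear direction. The estimated step is a 1.1-fold lower number from compound 1 to compound 3 (0.05 log units; within the scatter). Compound 3 is expected to give 2600 nM, within 900 nM to 7500 nM.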

Compound 3, half-maximal inhibitory concentration: 1020 nM
Compound 3: the middle estimate sits 2.5-fold (0.41 log units) above what was measured; the measured number falls inside the stated range.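

In this assay, the change from oxolan-3-yl to oxolan-2-yl gives a 2.9-fold lower number from compound 1 to compound 3 (0.46 log units; beyond the scatter). This shows that the number responds to how the ring is joined on a saturated chain carbon bound to an aromatic carbon and a saturated chain carbon, even though the atoms stay the same. The step remains modest, and repeats of a single compound span a similar distance: the several entries of compound 2 in this assay, 1310 nM; 427 nM (2 entries)

The compounds shown leave open whether the step would hold up over repeated entries of compound 1 and compound 3. They also leave open how a pyrrolidin-2-yl ring, which carries an amine, or a carboxylic acid would behave at this place.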